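A few compounds are considered here, and "the series" means these few. Any claim that something is new, unique, unknown or untested is made for them only; others in the source may bear on it.

In a functional assay on A-375 cells (Homo sapiens) for activation, with a stated time of 3 days (a higher number here means that more compound is needed for the effect, a lower number that less compound is needed), compound 1 (`O=C(Nc1ccc(-c2cscn2)cc1)C1CCCN(Cc2ccc(F)c(F)c2)C1`) gives 1240 nM while compound 2 (`O=C(Nc1ccc(-c2cscn2)cc1)C1CCN(Cc2ccc(F)c(F)c2)C1`) gives 8000 nM and compound 3 (`O=C(Nc1ccc(-c2ccccc2)cc1)C1CCCN(Cc2ccc(F)c(F)c2)C1`) gives 5000 nM as half-maximal effective concentrations. Compound 3 thus sits within the scatter of compound 2 and clearly apart from compound 1, on the higher side. The next structure is compound 4 (`O=C(Nc1ccc(-c2ccncc2)cc1)C1CCCN(Cc2ccc(F)c(F)c2)C1`), which has pyridin-4-yl in place of phenyl on an aromatic carbon, para to a large group (pyridin-4-yl in place of phenyl on an aromatic carbon). Within the data shown here, one measured step bears on this swap. Putting phenyl in place of 1,3-thiazol-4-yl gave a 4.0-fold higher number from compound 1 to compound 3 (0.61 log units; beyond the scatter) and so left the ring with hetero atoms at the lower number. Among the measured compounds shown here, that is a single comparison, and pyridin-4-yl is a different ring with no measured example yet, so only part of that step is expected to carry over. The expected change is a modest move to a lower number (a 2.3-fold lower number from compound 3 to compound 4 (0.36 log units; beyond the scatter)) close to the edge of the scatter. For compound 4 the estimated value is 2200 nM (expected range 700 nM to 6500 nM).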

Compound 4, half-maximal effective concentration: 1180 nM
For compound 4 the middle estimate is 1.9-fold (0.27 log units) above the measured one; the range from low to high includes it.
By their numbers in this assay, from the lowest: compounds 4 and 1 (each within the scatter of the next); then compounds 3 and 2 (each within the scatter of the next).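

In this assay, pyridin-4-yl in place of phenyl gives a 4.2-fold lower number from compound 3 to compound 4 (0.63 log units; beyond the scatter), so a second ring with a hetero atom, alongside the 1,3-thiazol-4-yl of compound 1, now stands clear of phenyl at this place, para to a large group. Pyridin-4-yl in place of 1,3-thiazol-4-yl gives a 1.1-fold lower number from compound 1 to compound 4 (0.02 log units; within the scatter), so these two rings cannot be told apart in this assay, even though one is six-membered and the other is not. Nothing at hand explains why phenyl differs from these two rings.

How pyridin-3-yl or pyrimidin-5-yl would fare at this place remains open, so the compounds shown do not tell whether the location or number of ring nitrogens matters. Also open, as far as these compounds go, is whether pyridin-4-yl would give the same step on the core of compound 2.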